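The source may hold more compounds than are shown below. What is called first, only, known or untested is meant among the compounds shown, and "the series" means these compounds.

In a functional assay (aorta) with Oryctolagus cuniculus as the target (a higher number here means weaker binding, a lower number tighter binding), three compounds sharing one core have been measured. Compound 1 `COc1cc(C(C)=O)ccc1OCCCCCN1CCC(C(c2ccc(F)cc2)c2ccc(F)cc2)CC1` gives 3.16 nM, compound 2 `COc1cc(C(C)=O)ccc1OCCCCCCN1CCC(C(c2ccc(F)cc2)c2ccc(F)cc2)CC1` gives 6.31 nM, and compound 3 `COc1cc(OCCCN2CCC(C(c3ccc(F)cc3)c3ccc(F)cc3)CC2)ccc1C(C)=O` gives 3.16 nM. Compound 3 thus stands level with compound 1, and all three values lie within the usual scatter of one another. Compound 4 `CC(C)(C)c1ccc(OCCCN2CCC(C(c3ccc(F)cc3)c3ccc(F)cc3)CC2)cc1` keeps the core and differs from compound 3 in one place: 4-(tert-butyl)phenyl in place of 4-acetyl-3-methoxyphenyl on an oxygen on a saturated carbon. Among the compounds with values here, no step between measured compounds shows what such a swap does, so only a modest shift towards a higher number in this assay, somewhat beyond the scatter, is expected. The estimated change is a 3.8-fold higher number from compound 3 to compound 4 (0.58 log units; beyond the scatter). Compound 4 is estimated at 12 nM, with an expected range of 3 nM to 50 nM.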

Compound 4, dissociation constant: 1 nM
Estimate against measurement, compound 4: 12-fold (1.08 log units) above; the whole stated range lies above it.
By their numbers in this assay, from the lowest: compound 4; then compounds 1, 3 and 2 (each within the scatter of the next).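

In this assay, within the data shown here, the change to 4-(tert-butyl)phenyl in place of 4-acetyl-3-methoxyphenyl on an oxygen on a saturated carbon gives a 3.2-fold lower number from compound 3 to compound 4 (0.50 log units; beyond the scatter) and is the first step here beyond the scatter. The position thus accepts an entering group with no hydrogen-bond acceptors, and the number falls rather than rises. Nothing given here bears on why the number falls. From the compounds shown here alone, the acetyl, the methoxy and the tert-butyl change together, so their separate shares stay open. A plain 4-methoxyphenyl, a 4-acetylphenyl or a 4-aminophenyl in this place would bear on that question.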